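From cyclohexyl to 2-methylphenyl on compound 2

The compounds below may be only part of what the source reports. "The series", "measured", "known", "first", "only" and "open" are said of these compounds alone.

Compound 1 `O=C(CCCCCNc1c(NCc2ccccc2)c(=O)c1=O)NO`: 5700000 nM
Compound 2 `O=C(CCCCCNc1c(NC2CCCCC2)c(=O)c1=O)NO`: 8700000 nM

These two values come from a physicochemical assay for solubility, with a stated time of 24 h, tested at 30 mg/mL; a higher number here means a more soluble compound, a lower number a less soluble compound. Going by the values given here, the only measured step is a 1.5-fold higher number from compound 1 to compound 2 (0.18 log units; within the scatter), so compound 2 cannot be ranked on these numbers. Its value stands level, within the usual scatter, with the only other one measured.

Compound 3 `Cc1ccccc1Nc1c(NCCCCCC(=O)NO)c(=O)c1=O` has not yet been measured. It carries 2-methylphenyl in place of cyclohexyl on a nitrogen on an aromatic ring.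

One measured step is a thin guide, but it changed a group at this same place and stayed small. No step beyond the scatter is therefore expected in this assay, though a slightly lower number is possible. The expected change is a 1.7-fold lower number from compound 2 to compound 3 (0.24 log units; within the scatter). For compound 3 the estimated value is 5000000 nM, with an expected range of 2000000 nM to 11000000 nM.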

Compound 3, solubility: 12000000 nM
The estimate for compound 3 lay 2.4-fold (0.38 log units) below the measured number, and the stated range ends below it.
By their numbers in this assay, from the lowest: compounds 1, 2 and 3 (each within the scatter of the next, the first and the last beyond it).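

At this position on the nitrogen, a six-membered aromatic ring of carbon can replace the non-aromatic cyclohexyl ring in this assay with only a small step, one that stays inside the usual scatter (a 1.4-fold higher number from compound 2 to compound 3 (0.14 log units; within the scatter)). Going by these compounds alone, the same compound also gives the first step in this short series that lies beyond the scatter, though only modestly (a 2.1-fold higher number from compound 1 to compound 3 (0.32 log units; beyond the scatter)), so replacing benzyl with 2-methylphenyl is the one change here that separates two compounds. No evidence is available to explain either step.

The compounds shown cannot separate the effect of the aromatic ring from that of its methyl group, which plain phenyl on the same nitrogen could begin to do. From the compounds shown here alone, how a group carrying an amine or a carboxylic acid at this place would compare also remains open.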